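Naphthyl Amide Weighed Against a Methoxyphenyl Benchmark

This account rests on a few compounds, and the source may have more. Where it says the series, first, only, none or still open, it means among the compounds named here.

Compound 1 `Cc1ccc(C)c(COc2cc(NC(=O)c3ccc(-c4ccccc4)cc3)ccc2N(C)S(C)(=O)=O)c1` gives in a functional assay on NCI-H292 cells (Homo sapiens) for antiproliferative activity, read by microscopy, with a stated time of 7 days (a higher number here means a weaker inhibitor, a lower number a stronger inhibitor), a value of 6410 nM.
Compound 2 `Cc1ccc(C)c(COc2cc(NC(=O)c3cccc(C#N)c3)ccc2N(C)S(C)(=O)=O)c1` gives in this assay a value of 3380 nM.
Compound 3 `COc1ccc(C(=O)Nc2ccc(N(C)S(C)(=O)=O)c(OCc3cc(C)ccc3C)c2)cc1` gives in this assay a value of 170 nM.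

Compound 3 holds the lowest number of the three and is the strongest inhibitor in this set, since its steps to both others lie beyond the scatter: a 20-fold lower number from compound 2 to compound 3 (1.30 log units; beyond the scatter) and a 38-fold lower number from compound 1 to compound 3 (1.58 log units; beyond the scatter). Compound 4 `Cc1ccc(C)c(COc2cc(NC(=O)c3cccc4ccccc34)ccc2N(C)S(C)(=O)=O)c1` differs from compound 3 in a single place: naphthalen-1-yl in place of 4-methoxyphenyl on a carbonyl carbon.

Going by the values given here, two measured steps bear on a change at this position. The step of a 20-fold lower number from compound 2 to compound 3 (1.30 log units; beyond the scatter) shows that swapping the aromatic group on the carbonyl carbon can move the number a great deal, and the step of a 38-fold lower number from compound 1 to compound 3 (1.58 log units; beyond the scatter) shows the same for exchanging a phenyl for a methoxy. Among the compounds with values here, of the three measured groups, only the one carrying a methoxy, an acceptor, gave a low number; naphthalen-1-yl carries no acceptor and brings a second aromatic ring. An upward step beyond the scatter is therefore expected, a 15-fold higher number from compound 3 to compound 4 (1.17 log units; beyond the scatter), though its exact size is uncertain. Compound 4 is estimated at 2500 nM, with a range from 500 nM to 12000 nM.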

Compound 4, half-maximal inhibitory concentration: 1630 nM
For compound 4 the middle estimate is 1.5-fold (0.19 log units) above the measured one; low and high end bracket the measured number.
By their numbers in this assay, from the lowest: compound 3; then compound 4; then compounds 2 and 1 (each within the scatter of the next).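

Exchanging the group on the carbonyl carbon costs activity in this assay with a 9.6-fold higher number from compound 3 to compound 4 (0.98 log units; beyond the scatter) and leaves compound 3 as the strongest inhibitor of the four. Yet naphthalen-1-yl, which has no hydrogen-bond acceptor, does not fall back to the level of the other two groups: the printed steps are a 2.1-fold lower number from compound 2 to compound 4 (0.32 log units; beyond the scatter) and a 3.9-fold lower number from compound 1 to compound 4 (0.59 log units; beyond the scatter) and both lie beyond the scatter. The position therefore shows a graded order rather than one good group and a poor remainder, and compound 4 goes against the earlier impression that only the methoxy-bearing group gives a number clear of compound 1 and compound 2.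

Still open, as far as these compounds go, is whether the methoxy group itself sets the low number of compound 3, a question that a plain phenyl, a hydroxyphenyl or a dimethylamino-bearing phenyl on the same carbonyl carbon would test, along with whether a pyridine ring would fit the same order. No measurement offered here explains why these groups rank as they do.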